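Removing a Fluorine from a Melanocortin Receptor Agonist

This account rests on a few compounds, and the source may have more. Where it says the series, first, only, none or still open, it means among the compounds named here.

Of the compounds shown here, two have so far been measured in a functional assay on CHO cells for agonist activity at Melanocyte-stimulating hormone receptor (Homo sapiens), read by a luciferase reporter, with a stated time of 4 h; on this read-out higher numbers stand for an effect only at larger amounts of compound and lower numbers for an effect already at smaller amounts. Compound 1 `COc1ccc(N(C(=O)CN2C=CN(Cc3ccccc3)C(=O)C(Cc3n[nH]c4ccccc34)C2=O)C(C)C)cc1` gives 794 nM. Compound 2 `COc1ccc(N(C(=O)CN2C=CN(c3cccnc3)C(=O)C(Cc3n[nH]c4cc(F)ccc34)C2=O)C(C)C)cc1` gives 12.6 nM, the lower of the two numbers, and its gap to compound 1 lies well beyond the usual scatter of repeated measurements. Compound 3 `COc1ccc(N(C(=O)CN2C=CN(c3cccnc3)C(=O)C(Cc3n[nH]c4ccccc34)C2=O)C(C)C)cc1` has not yet been measured in this assay. It differs from compound 2 in a single place: hydrogen in place of fluoro on an aromatic carbon. For the measured compounds named here, no pair of measured compounds shows this change on its own, so the size of its effect in this assay rests on expectation alone. A modest step towards a higher number is expected, a 2.0-fold higher number from compound 2 to compound 3 (0.30 log units; within the scatter), which stays close to the edge of the scatter. Compound 3 is therefore expected to give 25 nM in this assay, with a range from 8 nM to 80 nM.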

Compound 3, half-maximal effective concentration: 178 nM
The estimate for compound 3 lay 7.1-fold (0.85 log units) below the measured number; the measured number lies above the stated range.
By their numbers in this assay, from the lowest: compound 2; then compound 3; then compound 1.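

In this assay, this aromatic carbon proves far from indifferent to its substituent: hydrogen in place of fluoro gives a 14-fold higher number from compound 2 to compound 3 (1.15 log units; beyond the scatter), a large step. The change at the other site, pyridin-3-yl in place of benzyl on an amide-type nitrogen in a ring, can now also be read on its own and gives a 4.5-fold lower number from compound 1 to compound 3 (0.65 log units; beyond the scatter), a modest step. Nothing at hand accounts for the weight of the single fluorine atom at this carbon.

As far as these compounds go, it remains open whether chloro, methyl or methoxy on the same carbon would give a number nearer that of the fluoro compound or that of the hydrogen compound. From the compounds shown here alone, it also remains open whether fluoro at this carbon would have a step of similar size with benzyl on the ring nitrogen in place of pyridin-3-yl.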